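The source may report more compounds than this note shows. Statements on the series, on what has been measured and on what is new or still open speak of the compounds shown alone.

Compound 1 (`CC1(/C=C/c2ccccc2)C=CC(=O)O1`) gives 95300 nM in a functional assay on MCF7 cells (Homo sapiens) for inhibition, read by sulforhodamine B assay, with a stated time of 48 h (a lower number here means a stronger inhibitor of growth, a higher number a weaker inhibitor of growth), and it is the plain member of this small set. Compound 2 (`CC1(/C=C/c2ccccc2C(F)(F)F)C=CC(=O)O1`) gives 13500 nM and compound 3 (`CC1(/C=C/c2ccc(C(F)(F)F)cc2)C=CC(=O)O1`) gives 20400 nM in this assay, two values that lie within the usual scatter of each other. Compound 3 thus stands level with compound 2 and clearly under compound 1. Trifluoromethyl in place of hydrogen on an aromatic carbon gave a 7.1-fold lower number from compound 1 to compound 2 (0.85 log units; beyond the scatter) and also a 4.7-fold lower number from compound 1 to compound 3 (0.67 log units; beyond the scatter) in the same measurement, both beyond the scatter.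

The change to compound 4 (`CC1(/C=C/c2ccc(F)cc2)C=CC(=O)O1`) is fluoro in place of trifluoromethyl on an aromatic carbon in one place, fluoro in place of trifluoromethyl on an aromatic carbon. For the measured compounds named here, no measured step makes this exchange, and no fluoro compound has a value yet. The closest guide is the step of a 4.7-fold lower number from compound 1 to compound 3 (0.67 log units; beyond the scatter) as compound 4 keeps a substituent where compound 3 has trifluoromethyl and compound 1 has hydrogen. Compound 4 is therefore expected to fall between those two, giving back part of that step. The expected step is a 2.0-fold higher number from compound 3 to compound 4 (0.29 log units; within the scatter) in this assay, a small move to a higher number, near the edge of the scatter. For compound 4 the estimated value is 40000 nM, with an expected range from 16000 nM to 90000 nM in this assay.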

Compound 4, concentration for total growth inhibition: 38500 nM
Estimate against measurement, compound 4: 1.0-fold (0.02 log units) above, and the stated range covers the measured number.
By their numbers in this assay, from the lowest: compounds 2, 3 and 4 (each within the scatter of the next, the first and the last beyond it); then compound 1.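

In this assay, for the compounds shown here, the position para to a group of 9 heavy atoms now carries a second kind of substituent: fluoro in place of hydrogen gives a 2.5-fold lower number from compound 1 to compound 4 (0.39 log units; beyond the scatter), beyond the scatter, so trifluoromethyl is not the only group there that separates a compound from the plain compound 1. Fluoro in place of trifluoromethyl gives a 1.9-fold higher number from compound 3 to compound 4 (0.28 log units; within the scatter), within the scatter, so this assay does not tell the two groups apart at this position, even though trifluoromethyl has 4 heavy atoms and fluoro has 1. Nothing measured here explains either step.

The compounds shown carry only halogen-containing groups on the aromatic ring, so it remains open whether a group such as an amine, a methoxy or a carboxylic acid at this position would give a number like those of compound 3 and compound 4 or one like that of compound 1. Going by these compounds alone, it also remains open whether fluoro would match trifluoromethyl at the other ring position, the one substituted in compound 2.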